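This account rests on a few compounds, and the source may have more. Where it says the series, first, only, none or still open, it means among the compounds named here.

Compound 1, `NCc1csc(NC(=O)c2ccc(Cl)cc2)n1`, was tested in a physicochemical assay for solubility, read by nephelometry, measured as kinetic solubility, at pH 2.0; a higher number here means a more soluble compound, a lower number a less soluble compound. In this assay compound 1 gives > 100 ug/mL, which is a limit of the assay and not a number. Two other compounds with the shared core were measured alongside it. Compound 2, `NCc1csc(NC(=O)c2cc3ccccc3[nH]2)n1`, gives > 100 ug/mL in this assay, again a limit. Compound 3, `NCc1csc(NC(=O)c2cnnn2Cc2ccccc2)n1`, gives > 100 ug/mL in this assay, also a limit. Among the measured compounds shown here, compound 1 therefore stands at the limit of > 100 ug/mL in this assay, at which 3 of the 3 values shown sit, and nothing in these values separates it from compound 2 or compound 3, so no step between measured compounds can be drawn.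

Compound 4, `NCc1csc(NC(=O)c2ccccc2)n1`, is not yet measured in this assay. It differs from compound 1 by hydrogen in place of chloro on an aromatic carbon. Because compound 1 already sits at the limit of > 100 ug/mL in this assay, at which 3 of the 3 values shown sit, the step from compound 1 to compound 4 is expected to be none beyond the scatter, as a step that the limit leaves unreadable from compound 1 to compound 4. The estimate for compound 4 in this assay is 150 ug/mL, with a range from 80 ug/mL to 300 ug/mL, and the assay is expected most likely to report a limit again.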

Compound 4, solubility: > 100 ug/mL
Compound 4: a limit, no number; the forecaster's own chance of this, stated with the estimate: 85%; the middle value is on the limit's open side.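

Compound 4, like compound 1, gives only a limit, so no step can be read between compound 1 and compound 4 in this assay: the limit of > 100 ug/mL in this assay, at which 4 of the 4 values shown sit. The compounds shown leave open how soluble each one actually is, and whether hydrogen and chloro differ at all in this read-out.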